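A Carbamoyl Group Enters a Series Held at a Limit

The source may hold more compounds than are shown below. What is called first, only, known or untested is meant among the compounds shown, and "the series" means these compounds.

In an ADME assay on LLC-MK2 cells (Macaca mulatta) for cytotoxicity, read by spectrophotometry and crystal violet staining, with a stated time of 4 days (on this read-out lower numbers stand for higher toxicity in this test and higher numbers for lower toxicity in this test), compound 1 `CC(C)n1ncc2c(C(=O)Nc3ccc(F)cc3)cc(-c3cccs3)nc21` gives > 200000 nM as a limit. Compound 2 `CC(C)n1ncc2c(C(=O)Nc3c(F)cccc3F)cc(-c3cccs3)nc21` gives > 200000 nM as a limit too. Compound 3 `CC(C)n1ncc2c(C(=O)Nc3c(F)cc(F)cc3F)cc(-c3cccs3)nc21` gives > 200000 nM as a limit as well. Compound 3 thus stands at the limit of > 200000 nM in this assay, at which 3 of the 3 values shown sit, and has no exact number. Among the measured compounds shown here, compound 4 `CC(C)n1ncc2c(C(=O)Nc3cc(C(N)=O)ccc3F)cc(-c3cccs3)nc21` carries 5-carbamoyl-2-fluorophenyl in place of 2,4,6-trifluorophenyl on an amide-type nitrogen as its one change. For the measured compounds named here, three measured steps bear on this change: a step that the two limits leave unreadable from compound 1 to compound 2 and a step that the two limits leave unreadable from compound 1 to compound 3 and a step that the two limits leave unreadable from compound 2 to compound 3 and none gives a size to carry over. The expected change is a number no higher from compound 3 to compound 4 (the limit leaves the size open) in this assay with no step beyond the scatter in either direction. The estimated value for compound 4 is 200000 nM with an expected range of 100000 nM to 400000 nM on repeated measurement.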

Compound 4, half-maximal cytotoxic concentration: 25000 nM
Compound 4: the middle estimate sits 8.0-fold (0.90 log units) above what was measured, and the stated range ends above it.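

This position can move the read-out in this assay. The steps among compound 1, compound 2 and compound 3 cannot be read, yet 5-carbamoyl-2-fluorophenyl gives an at least 8.0-fold lower number from compound 3 to compound 4 (0.90 log units; beyond the scatter), an at least 8.0-fold lower number from compound 2 to compound 4 (0.90 log units; beyond the scatter) and an at least 8.0-fold lower number from compound 1 to compound 4 (0.90 log units; beyond the scatter), each pointing to higher toxicity in this test. Compound 4 alone comes off the limit: the limit of > 200000 nM in this assay, at which 3 of the 4 values shown sit.

The compounds shown leave the carbamoyl group and the change in fluorines tied together in one step. On these data alone, how a carboxylic acid or an amine would read in place of the carbamoyl group also stays open.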